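Difluorophenyl step from compound 2 to compound 3

This account rests on a few compounds, and the source may have more. Where it says the series, first, only, none or still open, it means among the compounds named here.

Measured so far in a functional assay on A549 cells (Homo sapiens) for cytotoxicity, read by MTT assay, with a stated time of 48 h (on this read-out higher numbers stand for weaker inhibition and lower numbers for stronger inhibition), are these two compounds:
- compound 1 `COc1cc(-n2c(-c3ccc(O)cc3)c[nH]c2=O)cc(OC)c1OC` gives > 50000 nM as a limit
- compound 2 `COc1cc(-n2c(-c3ccccc3)cn(C(C)=O)c2=O)cc(OC)c1OC` gives > 50000 nM as a limit

Compound 2 gives > 50000 nM in this assay as a limit, not a number. Among the compounds with values here, its standing is shared by the only other measured compound, as the limit of > 50000 nM in this assay, at which 2 of the 2 values shown sit, shows.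

The next compound to be measured is compound 3 `COc1cc(-n2c(-c3ccc(F)cc3F)cn(C(C)=O)c2=O)cc(OC)c1OC` with 2,4-difluorophenyl in place of phenyl on an aromatic carbon. Within the data shown here, no step between measured compounds is available to size this change in this assay on the series' own evidence. The most likely expectation is no step beyond the scatter, and a further limit reading would fit that expectation. With compound 2 at > 50000 nM as a limit, only a move towards stronger inhibition could appear as a number.

The expected size of the change is an at least 1.2-fold lower number from compound 2 to compound 3 (0.09 log units; that floor lies within the scatter) on this estimate. For compound 3 the estimated value is 40000 nM with an expected range from 10000 nM to 100000 nM in this assay for now.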

Compound 3, half-maximal inhibitory concentration: 24100 nM
Beside the measured number, compound 3's estimate is 1.7-fold (0.22 log units) above it, within the range that was stated.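

In this assay, 2,4-difluorophenyl in place of phenyl on an aromatic carbon gives the only reading of the series that is a number and not a limit, while the other compounds stay at the assay's ceiling: the limit of > 50000 nM in this assay, at which 2 of the 3 values shown sit.

The change gives an at least 2.0-fold lower number from compound 2 to compound 3 (0.31 log units; beyond the scatter); this is a floor, and the full size of the step cannot be read from a limit. With the acetyl group and the shared core unchanged, the series now shows that the read-out responds to the aryl group on this aromatic carbon of the five-membered aromatic ring, next to the ring nitrogen, which the two limit readings alone could not show.

The compounds shown leave open whether the step needs both fluorines or whether a phenyl carrying a single fluorine, a chlorophenyl or an aminophenyl at the same place would give a number too. Within the data shown here, they also leave open whether the acetyl group is needed for this reading, since no compound pairs 2,4-difluorophenyl with the free ring nitrogen.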